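The source may hold more compounds than are shown below. What is called first, only, known or untested is meant among the compounds shown, and "the series" means these compounds.

In an assay on Sf9 cells for inhibition of protein deacetylase HDAC6 (Homo sapiens), read by fluorescence, with a stated time of 90 min (a lower number here means a stronger inhibitor, a higher number a weaker inhibitor), compound 1, `COc1c(-c2ccccc2)c2ccccc2n(Cc2ccc(C(=O)NO)cc2)c1=O`, gives 61.6 nM. Compound 2, `O=C(NO)c1ccc(Cn2c(=O)c(OCc3ccccc3)c(-c3ccccc3)c3ccccc32)cc1`, carries the change (phenyl in place of hydrogen on a saturated chain carbon bound to an oxygen on an aromatic ring), and in this assay compound 2 gives 84.5 nM; the step of a 1.4-fold higher number from compound 1 to compound 2 (0.14 log units; within the scatter) is small. Compound 3, `Cn1c(=O)c(OCc2ccc(C(=O)NO)cc2)c(-c2cccnc2)c2ccccc21`, has a different core, and the difference between the two cores is not broken down here; in this assay compound 3 gives 46 nM. Compound 4, `O=C(NO)c1ccc(COc2c(-c3cccnc3)c3ccccc3n(Cc3ccccc3)c2=O)cc1`, differs from compound 3 by phenyl in place of hydrogen on a saturated chain carbon bound to an aromatic nitrogen. Its place is on a saturated chain carbon bound to an aromatic nitrogen, not one bound to an oxygen on an aromatic ring, so this is the same kind of change as before, not the same. The step is expected to be about a 1.3-fold higher number from compound 3 to compound 4 (0.12 log units; within the scatter), because the earlier one gave a 1.4-fold higher number from compound 1 to compound 2 (0.14 log units; within the scatter). For compound 4 the expected value is 60 nM, within 30 nM to 120 nM.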

Compound 4, half-maximal inhibitory concentration: 25.6 nM
Estimate against measurement, compound 4: 2.3-fold (0.37 log units) above; measured number below the stated range.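

In this assay, phenyl in place of hydrogen on a saturated chain carbon bound to an aromatic nitrogen gives a 1.8-fold lower number from compound 3 to compound 4 (0.25 log units; within the scatter), so this step is small. Set beside the earlier step, it shows no real difference in how the change behaves on the two cores: the same change on two cores in this assay, a 1.4-fold higher number (0.14 log units; within the scatter) from compound 1 to compound 2 and a 1.8-fold lower number (0.25 log units; within the scatter) from compound 3 to compound 4, 2.5-fold (0.39 log units) apart, within the scatter of two such steps. On these two pairs the change leaves the number within the scatter, but this does not show that it raises or lowers the number, and two pairs, with the change at different places, make no general rule.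

The compounds shown leave open whether an amine, a carboxylic acid or a longer chain at that place would move the number beyond the scatter. They also leave open how phenyl behaves on any other core.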